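This account rests on a few compounds, and the source may have more. Where it says the series, first, only, none or still open, it means among the compounds named here.

Compound 1, whose structure is `CCC(C)C1NC(=O)N(C2CCCC2)C1=O`, and compound 2, whose structure is `CC(C)C1NC(=O)N(C2CCCC2)C1=O`, share one core and differ only by methyl in place of hydrogen on a saturated chain carbon, two bonds along the chain from a saturated ring carbon. Each was tested in a functional assay on MIA PaCa-2 cells (Homo sapiens) for inhibition; a lower number here means a stronger inhibitor, a higher number a weaker inhibitor. In this assay compound 1 gives > 100000 nM, which is a limit of the assay rather than a number. Compound 2 likewise gives > 100000 nM, again a limit. The step between them is therefore a step that the two limits leave unreadable from compound 2 to compound 1. Compound 3, whose structure is `CC(C)C(NC(=O)n1nnc2ccccc21)C(=O)NC1CCCC1`, has a different core; the difference between the two cores is not broken down here. In this assay compound 3 gives > 100000 nM, also a limit, so that the limit of > 100000 nM in this assay, at which 3 of the 3 values shown sit, describes every value shown.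

Compound 4, whose structure is `CCC(C)C(NC(=O)n1nnc2ccccc21)C(=O)NC1CCCC1`, is not yet measured and differs from compound 3 by methyl in place of hydrogen on a saturated chain carbon, three bonds along the chain from an amide-type nitrogen and a carbonyl carbon. This is the same kind of change as from compound 2 to compound 1, though not the same, since its place is three bonds along the chain from an amide-type nitrogen and a carbonyl carbon rather than two bonds from a saturated ring carbon. Since compound 3 gives only > 100000 nM, the step that the limit leaves unreadable from compound 3 to compound 4 is expected to stay small. Compound 4 is estimated to give about 150000 nM in this assay, most probably again a limit.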

Compound 4, half-maximal inhibitory concentration: >= 100000 nM
Compound 4: a limit, no number (the forecaster's own chance of this, stated with the estimate: 85%); the middle value does not contradict the limit.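

In this assay compound 4 gives >= 100000 nM, which is a limit of the assay and not a number. For the compounds shown here, compound 3 also stands at a limit, so no step between compound 3 and compound 4 can be read. The compounds shown leave open how strongly any of them inhibits, and whether methyl in place of hydrogen changes anything in this assay.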